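The source may hold more compounds than are shown below. What is called first, only, known or untested is meant among the compounds shown, and "the series" means these compounds.

Working notes on the hydrazone aryl series.

Three analogues sharing one core have been measured in a functional assay on NCI-H460 cells (Homo sapiens) for cytotoxicity, read by MTT assay, with a stated time of 72 h; on this read-out lower numbers stand for stronger inhibition and higher numbers for weaker inhibition. Compound 1 `CN(C)CCn1cnnc1-c1cc(Oc2ccc(NC(=O)N/N=C/c3cccc(O)c3)cc2F)ccn1` gives 780 nM. Compound 2 `CN(C)CCn1cnnc1-c1cc(Oc2ccc(NC(=O)N/N=C/c3cccc(Cl)c3Cl)cc2F)ccn1` gives 72 nM. Compound 3 `CN(C)CCn1cnnc1-c1cc(Oc2ccc(NC(=O)N/N=C/c3ccc(F)cc3)cc2F)ccn1` gives 1980 nM, the highest number of the three; the nearest is compound 1 and the furthest is compound 2. The steps among them all concern the aryl group on the carbon with a double bond to nitrogen: an 11-fold lower number from compound 1 to compound 2 (1.03 log units; beyond the scatter), a 2.5-fold higher number from compound 1 to compound 3 (0.40 log units; beyond the scatter) and a 28-fold higher number from compound 2 to compound 3 (1.44 log units; beyond the scatter).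

The next compound, compound 4 `COc1ccc(/C=N/NC(=O)Nc2ccc(Oc3ccnc(-c4nncn4CCN(C)C)c3)c(F)c2)c(OC)c1`, differs from compound 3 as follows: 2,4-dimethoxyphenyl in place of 4-fluorophenyl on a carbon with a double bond to nitrogen. For the measured compounds named here, no measured step involves the 2,4-dimethoxyphenyl group, so the prediction rests only on the spread of the three aryl swaps above. Those steps show that changing this aryl moves the number by a modest to large amount, and that compound 3 already sits at the top, so a lower number is the more likely direction, with a wide margin. For compound 4 a step of a 2.8-fold lower number from compound 3 to compound 4 (0.45 log units; beyond the scatter) is expected in this assay. The estimate for compound 4 is therefore 700 nM, expected within 200 nM to 2500 nM.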

Compound 4, half-maximal inhibitory concentration: 1570 nM
For compound 4 the middle estimate is 2.2-fold (0.35 log units) below the measured one; the range from low to high includes it.
By their numbers in this assay, from the lowest: compound 2; then compounds 1, 4 and 3 (each within the scatter of the next, the first and the last beyond it).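

In this assay, the 2,4-dimethoxyphenyl group brings two hydrogen-bond acceptors where 4-fluorophenyl has none, yet compound 4 cannot be told apart from either of its nearest neighbours (a 1.3-fold lower number from compound 3 to compound 4 (0.10 log units; within the scatter) and a 2.0-fold higher number from compound 1 to compound 4 (0.30 log units; within the scatter)), so neither of these swaps at this position gives a readable step. For the compounds shown here, two substituents on the aryl ring are also not enough for a low number: 2,3-dichlorophenyl and 2,4-dimethoxyphenyl each carry two, but the series shows a large gap between them (a 22-fold higher number from compound 2 to compound 4 (1.34 log units; beyond the scatter)), and compound 2 remains the only analogue with a low number. No measurement at hand offers an explanation for this gap.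

The compounds shown leave open whether the low number of compound 2 follows the two chlorine atoms or where they sit on the ring; a 2,4-dichlorophenyl or a 2,3-dimethoxyphenyl group would separate these two readings. Also open, on these data alone, is how an aryl ring carrying an amine or a carboxylic acid would read at this position.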